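Swapping an isobutoxy for a cyclohexyl on the aryl ring

The source may hold more compounds than are shown below. What is called first, only, known or untested is meant among the compounds shown, and "the series" means these compounds.

Of the compounds shown here, two have been measured in an assay on CHO cells for antagonist activity at transient receptor potential cation channel subfamily V member 1 (Homo sapiens), read by FLIPR; a higher number here means a weaker inhibitor, a lower number a stronger inhibitor. Compound 1 `CC(C(=O)NCc1ccc(C(F)(F)F)cc1N1CCC(c2ccc(F)cc2)CC1)c1ccc(NS(C)(=O)=O)c(F)c1` gives 0.9 nM in this assay. For the measured compounds named here, compound 2 `CC(C)COc1cc(C(F)(F)F)ccc1CNC(=O)C(C)c1ccc(NS(C)(=O)=O)c(F)c1` gives 0.8 nM in this assay, a number that sits within the usual scatter of the one for compound 1, so the two cannot be told apart on these data. Both share the same core, a propanamide carrying a fluoro and a methanesulfonamide on one aryl ring and a trifluoromethyl on the other; they differ in the group on an aromatic carbon of a six-membered aromatic ring of carbon only, which in compound 2 is an isobutoxy.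

Compound 3 `CC(C(=O)NCc1ccc(C(F)(F)F)cc1C1CCCCC1)c1ccc(NS(C)(=O)=O)c(F)c1` carries a cyclohexyl there instead. Compared with compound 2, the change is cyclohexyl in place of isobutoxy on an aromatic carbon. Going by the values given here, no pair of measured compounds isolates this change, so its effect cannot be read directly. Both groups that have been tried at this position give sub-nanomolar numbers, which suggests the position tolerates varied substituents. For compound 3 the step of a 1.9-fold higher number from compound 2 to compound 3 (0.27 log units; within the scatter) is expected to be small and within the scatter. Compound 3 is therefore estimated to give 1.5 nM in this assay, with a range from 0.5 nM to 5 nM.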

Compound 3, inhibition constant: 0.6 nM
Compound 3: middle estimate off by 2.5-fold (0.40 log units), on the high side; measured number inside the range.
By their numbers in this assay, from the lowest: compounds 3, 2 and 1 (each within the scatter of the next).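

In this assay, for the compounds shown here, putting cyclohexyl in place of isobutoxy gives a 1.3-fold lower number from compound 2 to compound 3 (0.12 log units; within the scatter), the first direct reading of a single change on this aromatic carbon. The two groups differ in more than size: isobutoxy is an open chain with an oxygen and 1 hydrogen-bond acceptor, while cyclohexyl is a six-membered non-aromatic ring of carbon only with 0 hydrogen-bond acceptors, yet this pair cannot be told apart on these numbers, so in this pair neither the oxygen nor the switch from chain to ring leaves a readable mark. No separate measurement is available to explain why the two groups read alike.

On these data alone, what a much smaller group such as a methoxy or a plain hydrogen would do at this place stays open, as does the outcome for an amine or a carboxylic acid, which would bring in very different atoms. As far as these compounds go, it is also open whether this swap would read the same way with a different group in place of the trifluoromethyl.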